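Urea aryl swap on a diaryl ether scaffold

This account rests on a few compounds, and the source may have more. Where it says the series, first, only, none or still open, it means among the compounds named here.

Measured so far:
compound 1, `CN(C)CCn1cnnc1-c1cc(Oc2ccc(NC(=O)Nc3ccc(Cl)c(C(F)(F)F)c3)cc2F)ccn1`, 1070 nM;
compound 2, `CN(C)CCCn1cnnc1-c1cc(Oc2ccc(NC(=O)Nc3ccc(Cl)c(C(F)(F)F)c3)cc2F)ccn1`, 7880 nM.

Both were tested in a functional assay on MDA-MB-231 cells (Homo sapiens) for antiproliferative activity, read by MTT assay, with a stated time of 72 h; a higher number here means a weaker inhibitor, a lower number a stronger inhibitor. Within the data shown here, compound 2 gives the highest number of the two; the only step recorded, a 7.4-fold higher number from compound 1 to compound 2 (0.87 log units; beyond the scatter), replaces dimethylamino with (dimethylamino)methyl on the saturated chain and moves the number upward by a modest amount beyond the scatter.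

Compound 3, `CN(C)CCCn1cnnc1-c1cc(Oc2ccc(NC(=O)Nc3ccc(F)c(F)c3)cc2F)ccn1`, keeps the longer chain of compound 2 and changes the urea end: 3,4-difluorophenyl in place of 4-chloro-3-(trifluoromethyl)phenyl on an amide-type nitrogen. Among the measured compounds shown here, no measured pair touches the aryl group on the urea nitrogen, so the single known step, which concerns the chain, does not bear on this change. The data offer no anchor for the direction or size of the effect, and compound 2 already stands at the high end of the range.

For the measured compounds named here, with no step to lean on, a cautious expectation is a number for compound 3 somewhat higher than that of compound 2, a 1.9-fold higher number from compound 2 to compound 3 (0.28 log units; within the scatter), with a wide band. The estimate for compound 3 in this assay is 15000 nM, between 4000 nM and 60000 nM.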

Compound 3, half-maximal inhibitory concentration: 25300 nM
Compound 3: middle estimate off by 1.7-fold (0.23 log units), on the low side; the measured number falls inside the stated range.
By their numbers in this assay, from the lowest: compound 1; then compound 2; then compound 3.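

In this assay, the aryl group on the urea nitrogen proves to be a second place where one change moves the number beyond the scatter: with the chain of compound 2 kept, 3,4-difluorophenyl in place of 4-chloro-3-(trifluoromethyl)phenyl on the amide-type nitrogen gives a 3.2-fold higher number from compound 2 to compound 3 (0.51 log units; beyond the scatter). Until now the only recorded change was on the chain, a 7.4-fold higher number from compound 1 to compound 2 (0.87 log units; beyond the scatter), and the new step shows that the urea end also affects the number, in the same upward direction among these three compounds. Nothing available here accounts for the rise seen with this swap.

Among these compounds, the swap is seen only with the chain of compound 2, so whether it has a similar effect with the chain of compound 1 remains open. Because the 3,4-difluorophenyl group differs from the 4-chloro-3-(trifluoromethyl)phenyl group in both of its substituents, the compounds shown cannot separate the chlorine from the trifluoromethyl; a 4-chlorophenyl or a 3-(trifluoromethyl)phenyl group on the same urea nitrogen would address that question.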